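The source may report more compounds than this note shows. Statements on the series, on what has been measured and on what is new or still open speak of the compounds shown alone.

Working notes on the series. In a functional assay on HeLa cells (Homo sapiens) for inhibition, read by MTT assay, with a stated time of 48 h (on this read-out lower numbers stand for stronger inhibition of growth and higher numbers for weaker inhibition of growth), compound 3 (`COc1ccc2c(c1)c(C1CC(c3ccccc3)=NN1C(=O)c1ccc(OC)nc1)cn2C`) gives 1100 nM and compound 2 (`COc1ccc(C2=NN(C(=O)c3cccnc3)C(c3cn(C)c4ccc(Br)cc34)C2)cc1`) gives 890 nM, so these two sit within the scatter of each other. Compound 1 (`COc1ccc(C(=O)N2N=C(c3ccccc3)CC2c2cn(C)c3ccccc23)cn1`) gives 3980 nM, clearly apart from compound 3.

The next change leads to compound 4 (`COc1ccc2c(c1)c(C1CC(c3cc(OC)c(OC)c(OC)c3)=NN1C(=O)c1ccc(OC)nc1)cn2C`), which keeps the core of compound 3 and carries 3,4,5-trimethoxyphenyl in place of phenyl on a carbon with a double bond to nitrogen.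

Among the compounds with values here, only one measured step offers guidance. Methoxy in place of hydrogen on an aromatic carbon gave a 3.6-fold lower number from compound 1 to compound 3 (0.56 log units; beyond the scatter), a modest step beyond the scatter. That step lies elsewhere in the molecule, so it bears on this change only loosely. Within the data shown here, no measured step changes the group at this carbon on its own. Compound 2 differs from compound 3 in more than one place, so its value offers no clean comparison.

A modest move toward a lower number in this assay is therefore expected, though a result within the scatter would not be surprising. The estimated step is a 2.8-fold lower number from compound 3 to compound 4 (0.44 log units; beyond the scatter). For compound 4 the estimated value is 400 nM, with an expected range of 100 nM to 1500 nM.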

Compound 4, concentration for 50% growth inhibition: > 10000 nM
Compound 4: only a limit was reported; the forecaster's own chance of this, stated with the estimate: 3%; middle value at least 25-fold (1.39 log units) away from the limit.
By their numbers in this assay, from the lowest: compounds 2 and 3 (each within the scatter of the next); then compound 1. At a limit, above all of these: compound 4.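

Within the data shown here, at the carbon with a double bond to nitrogen, replacing phenyl with 3,4,5-trimethoxyphenyl gives an at least 9.0-fold higher number from compound 3 to compound 4 (0.95 log units; beyond the scatter), the first measured step toward a higher number and the first to show that this position responds strongly to a change of group. Compound 4 reads > 10000 nM in this assay, which is a limit of the assay and not a number, so the step has a lower bound but no full size: the limit of > 10000 nM in this assay, at which 1 of the 4 values shown sits. Methoxy-bearing changes therefore do not all point the same way, since the earlier step, a 3.6-fold lower number from compound 1 to compound 3 (0.56 log units; beyond the scatter), goes toward a lower number elsewhere in the molecule, while 3,4,5-trimethoxyphenyl at this carbon goes toward a higher one.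

Open, as far as these compounds go, is whether a smaller replacement for phenyl at this carbon, such as a fluorophenyl or an aminophenyl group, would keep the number close to that of compound 3 or would also move it toward a higher number. Also open, from the compounds shown here alone, is whether the same change would have a similar effect on a version of the shared core carrying a different group in place of the (6-methoxypyridin-3-yl)carbonyl group.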